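The compounds below may be only part of what the source reports. "The series", "measured", "known", "first", "only" and "open" are said of these compounds alone.

Measured so far:
compound 1 `Cc1ccc(-c2nn(-c3ccccc3)cc2C(=O)NOCc2ccccc2)cc1` — 6690 nM
compound 2 `Cc1ccc(-c2nn(-c3ccccc3)cc2C(=O)NOCc2ccccc2F)cc1` — 1180 nM

Two compounds have been run in a functional assay on HeLa cells (Homo sapiens) for antiproliferative activity, read by MTT assay, with a stated time of 48 h, in the presence of a further agent that is not named here; on this read-out lower numbers stand for stronger inhibition of growth and higher numbers for weaker inhibition of growth. Compound 1 gives 6690 nM. For the measured compounds named here, compound 2 gives 1180 nM, the lowest of the two numbers; its nearest neighbour is compound 1, and the single measured step between them, a 5.7-fold lower number from compound 1 to compound 2 (0.75 log units; beyond the scatter), lies beyond the scatter. That step concerns the ring carried on the oxygen of the hydroxamate side chain, not the aryl group on the pyrazole core.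

Compound 3 `COc1ccc(-c2nn(-c3ccccc3)cc2C(=O)NOCc2ccccc2F)cc1` is not yet measured. It differs from compound 2 by methoxy in place of methyl on an aromatic carbon. Going by the values given here, no measured step bears on this position: the only step in hand exchanges hydrogen for fluoro on the other ring, so it gives no guide to what a change on the 4-methylphenyl group does. With nothing to go on but this, the expectation for compound 3 is a number close to that of compound 2, with no step beyond the scatter, a 1.0-fold higher number from compound 2 to compound 3 (0.01 log units; within the scatter). Compound 3 is therefore estimated at 1200 nM, within the range 450 nM to 3200 nM.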

Compound 3, concentration for 50% growth inhibition: 2900 nM
The estimate for compound 3 lay 2.4-fold (0.38 log units) below the measured number; low and high end bracket the measured number.
By their numbers in this assay, from the lowest: compound 2; then compound 3; then compound 1.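

In this assay, the 4-methylphenyl group turns out to be a position that responds to change: 4-methoxyphenyl in its place gives a 2.5-fold higher number from compound 2 to compound 3 (0.39 log units; beyond the scatter), a step beyond the scatter and the first measured at this position, whereas the earlier step concerned only the ring on the oxygen of the side chain. Within this single pair, the methyl group goes with the stronger inhibition of growth, and the swap to methoxy brings in an oxygen as well as a larger group, so the step alone cannot show which of these two differences matters. No measurement available here offers an explanation for the step.

Going by these compounds, it remains open whether an ethyl group, which is similar in size to methoxy but has no oxygen, would match the methyl or the methoxy result, and whether a chlorine or a hydroxyl group at this place would lie closer to either. The compounds shown also leave open whether the gain from fluoro in place of hydrogen on the other ring carries over when the 4-methoxyphenyl group is present.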